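This account rests on a few compounds, and the source may have more. Where it says the series, first, only, none or still open, it means among the compounds named here.

In a functional assay on HL-60 cells (Homo sapiens) for inhibition, read by CCK-8 assay, with a stated time of 48 h (on this read-out higher numbers stand for weaker inhibition and lower numbers for stronger inhibition), compound 1 (`COc1ccc(Oc2ccccc2-c2ccsc2S(=O)(=O)N2CCN(C(=S)Nc3ccc([N+](=O)[O-])cc3)CC2)cc1OC`) gives > 50000 nM which is a limit of the assay and not a number. In this assay compound 2 (`O=S(=O)(NCCNC(=S)Nc1cc(C(F)(F)F)cc(C(F)(F)F)c1)c1ccc(-c2ccccc2OCc2cccc(O)c2)s1`) gives > 50000 nM which is also a limit. In this assay compound 3 (`O=[N+]([O-])c1ccc(NC(=S)NCCNS(=O)(=O)c2ccc(-c3ccccc3O[C@H]3CC[C@@H](O)CC3)s2)cc1`) gives > 50000 nM and this too is a limit. Compound 1 therefore stands with the other two, and the record so far is the limit of > 50000 nM in this assay, at which 3 of the 3 values shown sit, with no true number to compare against.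

The next compound to be tested is compound 4 (`COc1ccc(Oc2ccc([N+](=O)[O-])cc2-c2ccsc2S(=O)(=O)N2CCN(C(=S)Nc3ccc([N+](=O)[O-])cc3)CC2)cc1OC`). It keeps the core of compound 1 and makes one change: nitro in place of hydrogen on an aromatic carbon In words, nitro takes the place of hydrogen on an aromatic carbon, meta to a large group and para to a 3,4-dimethoxyphenoxy group.

Among the measured compounds shown here, no measured pair of compounds shows what such a change does in this assay so the expectation has little to rest on. Most likely there is no step beyond the scatter, with some chance of a move towards stronger inhibition. The expected change is an at least 1.4-fold lower number from compound 1 to compound 4 (0.15 log units; that floor lies within the scatter) and it may well prove to be another limit. For compound 4 the estimate is 35000 nM with an expected range from 6000 nM to 50000 nM in the same test.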

Compound 4, half-maximal inhibitory concentration: > 50000 nM
Compound 4 ended at the assay's limit (the forecaster's own chance of this, stated with the estimate: 60%); at least 1.4-fold (0.15 log units) between middle value and limit.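

In this assay, among the compounds shown here, compound 4 sits at a limit of the assay just as compound 1 does, so no step from adding the nitro group can be read. The compounds shown leave open whether the nitro group changes inhibition at all, and which change, if any, would give a true number rather than a limit.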